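Swapping an Ester for Chlorine on a Shared Core

This account rests on a few compounds, and the source may have more. Where it says the series, first, only, none or still open, it means among the compounds named here.

Measured compounds:
compound 1 `O=C(OC1CCCCC1)c1ccc(NCc2cncn2Cc2ccc(-c3ccccc3)cc2)cc1-c1ccccc1` gives > 10000 nM in a toxicity assay on NIH3T3 cells (Mus musculus) for cytotoxicity, read by resazurin assay (a higher number here means that more compound is needed for the effect, a lower number that less compound is needed), a limit of the assay and not a number
compound 2 `COC(=O)c1ccc(NCc2cncn2Cc2ccc(F)cc2F)cc1-c1ccccc1` gives > 1000 nM in this assay, again a limit of the assay
compound 3 `COC(=O)c1ccc(NCc2cncn2Cc2ccccc2Br)cc1-c1ccccc1` gives 10000 nM in this assay

Compound 1 thus stands at a limit of this assay; of the three values shown, two are limits, as the limit of > 1000 nM in this assay, at which 1 of the 3 values shown sits, and the limit of > 10000 nM in this assay, at which 1 of the 3 values shown sits, record. Only compound 3 carries a number. Among the measured compounds shown here, the one step between measured compounds that differ in a single place, a step that the limit leaves unreadable from compound 2 to compound 3, cannot be read because one of its two values is a limit.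

Compound 4 `Clc1ccc(NCc2cncn2Cc2ccc(-c3ccccc3)cc2)cc1-c1ccccc1` differs from compound 1 by chloro in place of cyclohexyloxycarbonyl on an aromatic carbon. For the measured compounds named here, no measured step touches this position, and the only measured step of any kind is unreadable, so the data give no size for the change from an ester to a chlorine. Going by the values given here, what remains is that compound 1 sits at a limit and that compound 3, the only compound with a number, sits at the same concentration as that limit.

Compound 4 is therefore expected to give about 10000 nM, most likely between 3000 nM and 30000 nM, and quite possibly again only a limit. The step from compound 1 to compound 4 is expected to be a number no higher from compound 1 to compound 4 (the limit leaves the size open), none beyond the scatter.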

Compound 4, half-maximal effective concentration: > 1000 nM
Compound 4: no number, only a limit (the forecaster's own chance of this, stated with the estimate: 70%); the middle value lies beyond the limit too.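

Compound 1 and compound 4 both carry only limits in this assay, not numbers, and the step between them cannot be read. The compounds shown leave open how the amount of compound needed for the effect differs between chloro and cyclohexyloxycarbonyl on the shared core.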